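Shifting a diol one carbon outward on a bisphenol ether

This account rests on a few compounds, and the source may have more. Where it says the series, first, only, none or still open, it means among the compounds named here.

Compound 1 `CCC(CC)(c1ccc(OC[C@@H](O)CO)c(C)c1)c1ccc(OCC(C)(C)O)c(C)c1` is tested in an assay on HOS cells for agonist activity at vitamin D3 receptor (Homo sapiens), read by a luciferase reporter (on this read-out higher numbers stand for an effect only at larger amounts of compound and lower numbers for an effect already at smaller amounts), where compound 1 gives 163 nM. Going by the values given here, this is the higher of the two numbers known so far: compound 2 `CCC(O)(CC)COc1ccc(C(CC)(CC)c2ccc(OC[C@@H](O)CO)c(C)c2)cc1C` gives 18 nM, and the step is a 9.1-fold lower number from compound 1 to compound 2 (0.96 log units; beyond the scatter). The new compound 3 `CCC(CC)(c1ccc(OCC(CO)CO)c(C)c1)c1ccc(OCC(C)(C)O)c(C)c1` differs from compound 1 in the other side chain: 2-hydroxy-1-(hydroxymethyl)ethyl in place of 1,2-dihydroxyethyl on a saturated chain carbon bound to an oxygen on an aromatic ring, so the stereocentre of compound 1 is no longer present. Among the compounds with values here, the one measured step, from compound 1 to compound 2, concerns a different side chain, so no measured step bears directly on this change. With nothing to anchor it, the expected step is a 1.2-fold higher number from compound 1 to compound 3 (0.09 log units; within the scatter), small and not clearly beyond the usual scatter. Compound 3 is therefore estimated at 200 nM in this assay, with a range from 60 nM to 700 nM.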

Compound 3, half-maximal effective concentration: 76.5 nM
Compound 3: middle estimate off by 2.6-fold (0.42 log units), on the high side, and the stated range covers the measured number.
By their numbers in this assay, from the lowest: compound 2; then compound 3; then compound 1.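

Going by these compounds alone, the change from 1,2-dihydroxyethyl to 2-hydroxy-1-(hydroxymethyl)ethyl gives a 2.1-fold lower number from compound 1 to compound 3 (0.33 log units; beyond the scatter) in this assay, so the number depends on this side chain as well as on the one changed between the earlier compounds. The swap adds one carbon and removes the defined stereocentre while keeping the same count of hydrogen-bond donors and acceptors, and compound 3 shows that a defined stereocentre on this chain is not required for activity in this assay. No evidence is available on why the number moved.

On these data alone, it remains open whether a carboxylic acid or an amine would be tolerated at this position in place of the two hydroxyl groups. As far as these compounds go, it is also open whether this change and the 1-ethyl-1-hydroxypropyl group would add up in one molecule.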